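The source may report more compounds than this note shows. Statements on the series, on what has been measured and on what is new or still open speak of the compounds shown alone.

Three compounds share one core, a diamino-substituted bicyclic heteroaromatic linked through a short thiocarbamate-type tether to a piperazine that carries an aromatic ring. Compound 1, `Nc1nc(N)c2cc(CSC(=S)N3CCN(c4ccc(O)cc4)CC3)ccc2n1`, bears a hydroxyphenyl on that piperazine; compound 2, `Cc1ccccc1N1CCN(C(=S)SCc2ccc3nc(N)nc(N)c3c2)CC1`, bears a 2-methylphenyl; and compound 3, `Nc1nc(N)c2cc(CSC(=S)N3CCN(c4ccccc4Cl)CC3)ccc2n1`, bears a 2-chlorophenyl. In a functional assay on HeLa cells (Homo sapiens) for antiproliferative activity, read by MTT assay, with a stated time of 72 h (on this read-out lower numbers stand for stronger inhibition and higher numbers for weaker inhibition), compound 1 gives 5180 nM. In this assay compound 2 is recorded as "not determined" (no result reported), so no single number stands for compound 2, and nothing can be said about where it sits relative to compound 1.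

The step from compound 2 to compound 3 is chloro in place of methyl on an aromatic carbon. Within the data shown here, because no step between two measured compounds is available, the size and direction of this change in this assay cannot be read from the data; a shift within the usual scatter, in either direction, is as plausible as none at all. Among the measured compounds shown here, the only anchor is compound 1 with 5180 nM. On that basis compound 3 is expected to fall near 4500 nM in this assay, with a likely range from 1200 nM to 16000 nM.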

Compound 3, half-maximal inhibitory concentration: 4050 nM
For compound 3 the middle estimate is 1.1-fold (0.05 log units) above the measured one; measured number inside the range.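

In this assay, among these compounds, the swap of 4-hydroxyphenyl for 2-chlorophenyl on the piperazine nitrogen gives a 1.3-fold lower number from compound 1 to compound 3 (0.11 log units; within the scatter) and so offers the first readable comparison at this position, showing that these two aromatic groups cannot be told apart on this read-out. The methyl to chloro change itself cannot be read, as compound 2 has no number to set against compound 3, so the data say nothing about how a chloro compares with a methyl on this ring. Nothing in the data shown offers an explanation for what these compounds do in the cells.

The compounds shown leave open how a plain phenyl, with no substituent at all, would read on the same piperazine, and whether an amine or a carboxylic acid on that ring would move the number beyond the usual scatter. They also leave open whether a longer chain in place of the 2-chlorophenyl substituent's chloro would matter, and so how much this part of the molecule contributes to activity against these cells.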